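The source may hold more compounds than are shown below. What is called first, only, known or untested is meant among the compounds shown, and "the series" means these compounds.

Compound 2, `COc1ccc(S(=O)(=O)N2CCc3cccc(-c4ccc(F)cc4)c32)cc1`, gives 79 nM in a functional assay on MKN-45 cells (Homo sapiens) for inhibition, with a stated time of 72 h (on this read-out higher numbers stand for weaker inhibition and lower numbers for stronger inhibition), and stands second highest of the three numbers measured. Compound 1, `COc1ccc(S(=O)(=O)N2CCc3cccc(-c4ccc([N+](=O)[O-])cc4)c32)cc1`, gives 34 nM, and compound 3, `COc1ccc(S(=O)(=O)n2ccc3cccc(-c4ccc(F)cc4)c32)cc1`, gives 170 nM. Compound 4, `COc1ccc(S(=O)(=O)N2CCc3cccc(-c4ccc(N(C)C)cc4)c32)cc1`, differs from compound 2 in one place: dimethylamino in place of fluoro on an aromatic carbon. Going by the values given here, only one measured step bears on this position, a 2.3-fold higher number from compound 1 to compound 2 (0.37 log units; beyond the scatter), a modest step on exchanging one group for another at the same aromatic carbon. Nothing measured covers dimethylamino itself, so the step of a 1.1-fold lower number from compound 2 to compound 4 (0.05 log units; within the scatter) is expected to stay near the scatter, with no clear direction. In this assay compound 4 is therefore estimated at 70 nM, within a range of 20 nM to 250 nM.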

Compound 4, half-maximal inhibitory concentration: 237 nM
Estimate against measurement, compound 4: 3.4-fold (0.53 log units) below; low and high end bracket the measured number.
By their numbers in this assay, from the lowest: compound 1; then compound 2; then compounds 3 and 4 (each within the scatter of the next).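

The position tolerates no free exchange: in this assay, dimethylamino in place of fluoro gives a 3.0-fold higher number from compound 2 to compound 4 (0.48 log units; beyond the scatter), so this change moves the number beyond the scatter. With three groups now at this aromatic carbon, the numbers rise from nitro through fluoro to dimethylamino, and the two ends of that order are separated by a 7.0-fold higher number from compound 1 to compound 4 (0.84 log units; beyond the scatter). Nothing measured here accounts for this order. From the compounds shown here alone, whether a primary amine, a nitrile or a carboxylic acid at this carbon would fit the order remains open. Also open, going by these compounds, is whether dimethylamino would give a similar step on the core of compound 3.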